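This account rests on a few compounds, and the source may have more. Where it says the series, first, only, none or still open, it means among the compounds named here.

Among the compounds with values here, compound 3, `COc1ccc([C@@H]2CC(=O)c3c(O)cc(OCc4cn(Cc5ccccc5C)nn4)cc3O2)cc1O`, gives in a functional assay on RAW264.7 cells (Mus musculus) for inhibition, read by Griess assay, with stated times of 2 h and 24 h (on this read-out lower numbers stand for stronger inhibition and higher numbers for weaker inhibition), a value of 13100 nM, the lowest of the three numbers measured so far, though each of its neighbours lies within the usual scatter of it. Compound 2, `COc1ccc([C@@H]2CC(=O)c3c(O)cc(OCc4cn(C5CCC5)nn4)cc3O2)cc1O`, gives in this assay a value of 15300 nM, and compound 1, `COc1ccc([C@@H]2CC(=O)c3c(O)cc(OCc4cn(CCCO)nn4)cc3O2)cc1O`, gives in this assay a value of 16700 nM. None of the three steps among them leaves the scatter: a 1.1-fold lower number from compound 1 to compound 2 (0.04 log units; within the scatter), a 1.3-fold lower number from compound 1 to compound 3 (0.11 log units; within the scatter) and a 1.2-fold lower number from compound 2 to compound 3 (0.07 log units; within the scatter).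

Compound 4, `CCCn1cc(COc2cc(O)c3c(c2)O[C@H](c2ccc(OC)c(O)c2)CC3=O)nn1`, differs from compound 3 at the group carried on the saturated chain carbon bound to an aromatic nitrogen: ethyl in place of 2-methylphenyl on a saturated chain carbon bound to an aromatic nitrogen. Two of the measured steps bear directly on this place. The exchange of 2-hydroxyethyl for 2-methylphenyl there gave a 1.3-fold lower number from compound 1 to compound 3 (0.11 log units; within the scatter), and the exchange of cyclobutyl for 2-methylbenzyl on the aromatic nitrogen gave a 1.2-fold lower number from compound 2 to compound 3 (0.07 log units; within the scatter). Both remained within the scatter, so this part of the molecule has so far tolerated a hydroxyalkyl chain, a small saturated ring and an aromatic ring without a reliable shift in this assay. On that basis compound 4 is expected to show no step beyond the scatter, that is a 1.1-fold higher number from compound 3 to compound 4 (0.04 log units; within the scatter). The estimate for compound 4 in this assay is therefore 14500 nM, with a likely range from 7000 nM to 30000 nM.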

Compound 4, half-maximal inhibitory concentration: 9670 nM
Beside the measured number, compound 4's estimate is 1.5-fold (0.18 log units) above it, within the range that was stated.
By their numbers in this assay, from the lowest: compounds 4, 3, 2 and 1 (each within the scatter of the next).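

Replacing 2-methylphenyl with ethyl on a saturated chain carbon bound to an aromatic nitrogen removes the aromatic ring from this substituent, yet this assay gives a 1.4-fold lower number from compound 3 to compound 4 (0.13 log units; within the scatter), so the compounds shown do not require that ring for a value in this range. The simple propyl group on the aromatic nitrogen likewise cannot be told apart from cyclobutyl, with a 1.6-fold lower number from compound 2 to compound 4 (0.20 log units; within the scatter), and removing the terminal hydroxy of the 3-hydroxypropyl group gives a 1.7-fold lower number from compound 1 to compound 4 (0.24 log units; within the scatter), which extends the tolerance seen so far to an unadorned short chain. No evidence is available to explain these small steps.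

Whether an amine, a carboxylic acid or a longer chain such as octyl in this place would produce a step beyond the scatter remains open, since all four compounds shown lie within the scatter of one another. Also open, from the compounds shown here alone, is how changes to the shared core, which is the same in all four compounds, would affect the number in this assay.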